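A few compounds are considered here, and "the series" means these few. Any claim that something is new, unique, unknown or untested is made for them only; others in the source may bear on it.

Measured compounds:
- compound 1 `C=C(C)[C@@H]1CC=C(Cn2cc(COc3cccc(C4NC(=O)NC(C)=C4C(=O)OCC)c3)nn2)CC1`: in a functional assay on MCF7 cells (Homo sapiens) for inhibition, read by sulforhodamine B assay, with a stated time of 48 h (a lower number here means a stronger inhibitor of growth, a higher number a weaker inhibitor of growth), compound 1 gives 42500 nM
- compound 2 `C=C(C)[C@@H]1CC=C(Cn2cc(COc3cc(C4NC(=O)NC(C)=C4C(=O)OCC)ccc3OC)nn2)CC1`: in this assay compound 2 gives only a limit, > 100000 nM
- compound 3 `C=C(C)[C@@H]1CC=C(Cn2cc(COc3ccc(C4NC(=O)NC(C)=C4C(C)=O)cc3)nn2)CC1`: in this assay compound 3 gives 29000 nM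

Notes. The values of compound 1 and compound 3 lie within the usual scatter of each other, so no order between them is drawn. The difference between the two cores of compound 1 and compound 3 is not broken down here. The step of an at least 2.3-fold higher number from compound 1 to compound 2 (0.37 log units; beyond the scatter) rests on the change methoxy in place of hydrogen on an aromatic carbon and on (the limit of > 100000 nM in this assay, at which 1 of the 3 values shown sits), so its true size may be larger than the figure shows.

Compound 4 `C=C(C)[C@@H]1CC=C(Cn2cc(COc3ccc(C4NC(=O)NC(C)=C4C(C)=O)cc3OC)nn2)CC1` has not yet been measured. It differs from compound 3 by methoxy in place of hydrogen on an aromatic carbon. This is the same kind of change as that from compound 1 to compound 2, though the place is not identical: in compound 2 the entering group is ortho to a large group and para to a large group, in compound 4 it is ortho to a large group and meta to a large group.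

For compound 4 a step of about a 2.4-fold higher number from compound 3 to compound 4 (0.38 log units; beyond the scatter) in this assay is expected, resting on the step of an at least 2.3-fold higher number from compound 1 to compound 2 (0.37 log units; beyond the scatter), which was at least modest. Compound 4 is therefore estimated at 70000 nM, with a range of 30000 nM to 150000 nM, and a real chance that only a limit is reported.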

Compound 4, concentration for total growth inhibition: 53300 nM
Beside the measured number, compound 4's estimate is 1.3-fold (0.12 log units) above it; measured number inside the range.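

In this assay, methoxy in place of hydrogen on an aromatic carbon gives a 1.8-fold higher number from compound 3 to compound 4 (0.26 log units; within the scatter), so on the core of compound 3 the change cannot be separated from the scatter. The earlier step, an at least 2.3-fold higher number from compound 1 to compound 2 (0.37 log units; beyond the scatter), lies beyond the scatter, but this does not show that the change carries over unchanged or that it fails to carry over, and the entering methoxy also stands differently in the two pairs: the same change on two cores in this assay, an at least 2.3-fold higher number (0.37 log units; beyond the scatter) from compound 1 to compound 2 and a 1.8-fold higher number (0.26 log units; within the scatter) from compound 3 to compound 4; the limit leaves it open whether they differ Compound 2 is known only as a limit, > 100000 nM, so the true size of the earlier step stays unknown: the limit of > 100000 nM in this assay, at which 1 of the 4 values shown sits.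

The compounds shown leave open whether another group in the same place, such as a hydroxy group, an amine or a longer alkoxy chain, would give a step that can be read on both cores. They also leave open how methoxy behaves on either core at any place other than those in compound 2 and compound 4.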